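This account rests on a few compounds, and the source may have more. Where it says the series, first, only, none or still open, it means among the compounds named here.

Measured so far:
- compound 1 `CCc1ccc(NC(=O)Nc2cc(C)nc3ccccc23)cc1`: 3300 nM
- compound 2 `Cc1cc(NC(=O)Nc2cccc3nsnc23)c2ccccc2n1`: 300 nM
- compound 3 `Cc1cc(NC(=O)Nc2cccc(Cl)c2)c2ccccc2n1`: 800 nM

In a physicochemical assay for solubility, at pH 7.4 (on this read-out higher numbers stand for higher solubility and lower numbers for lower solubility), compound 1 gives 3300 nM, the highest of the three numbers. Compound 3 is nearest to it at 800 nM, a gap beyond the usual scatter, and compound 2 is furthest at 300 nM, also beyond the scatter. Among the measured compounds shown here, no pair of these measured compounds differs in a single place, so no measured step is available to guide the next change.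

Compound 4 `COc1ccc(NC(=O)Nc2cc(C)nc3ccccc23)cc1` is not yet measured. It differs from compound 1 by methoxy in place of ethyl on an aromatic carbon of a six-membered aromatic ring of carbon only. The change keeps the heavy-atom count and adds one hydrogen-bond acceptor. With no measured step of this kind in the set, the expectation rests on compound 1 alone. Compound 4 is expected to come out close to compound 1, with the step from compound 1 to compound 4 estimated as a 1.4-fold higher number from compound 1 to compound 4 (0.13 log units; within the scatter), a small rise at most and possibly none beyond the scatter. The estimate for compound 4 in this assay is 4500 nM, within a range from 1800 nM to 11000 nM.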

Compound 4, solubility: 19800 nM
Beside the measured number, compound 4's estimate is 4.4-fold (0.64 log units) below it, and the stated range ends below it.
By their numbers in this assay, from the lowest: compound 2; then compound 3; then compound 1; then compound 4.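

In this assay, among the compounds shown here, methoxy in place of ethyl on an aromatic carbon, para to a large group, gives the first measured single-place step: a 6.0-fold higher number from compound 1 to compound 4 (0.78 log units; beyond the scatter). This shows that the read-out at this position is sensitive to the identity of the group, even with the heavy-atom count unchanged; of the two groups, only methoxy brings a hydrogen-bond acceptor and an oxygen. Nothing available explains the size of this step.

A single pair cannot show whether the step follows from the oxygen, the acceptor or something else specific to methoxy, and ethoxy, hydroxyl or dimethylamino at this position would test that further. Going by these compounds, whether the same exchange gives a similar step at another place on this ring also remains open.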